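Acetamido in place of pyridin-4-yl: expected step

The compounds below may be only part of what the source reports. "The series", "measured", "known", "first", "only" and "open" are said of these compounds alone.

Among the measured compounds shown here, in a functional assay on the whole organism (heart) with Canis familiaris (Canis lupus familiaris) as the target (on this read-out lower numbers stand for an effect already at smaller amounts and higher numbers for an effect only at larger amounts of compound), compound 1 `O=C1CCC(c2ccc(-c3ccccc3)cc2)=NN1` gives 0.513 mg/kg as its reading, and compound 2 `O=C1CCC(c2ccc(-c3ccncc3)cc2)=NN1` gives 0.146 mg/kg as the lower of the two numbers so far. For the measured compounds named here, the one measured step is a 3.5-fold lower number from compound 1 to compound 2 (0.55 log units; beyond the scatter) with pyridin-4-yl in place of phenyl on an aromatic carbon, and it is modest in size.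

Compound 3 `CC(=O)Nc1ccc(C2=NNC(=O)CC2)cc1` is still unmeasured and carries acetamido in place of pyridin-4-yl on an aromatic carbon. The measured step bears on this change only loosely. Going by the values given here, it exchanged one six-membered aromatic ring for another, whereas acetamido has no ring, and no measured compound carries that group.

Of the two measured compounds only compound 2 carries pyridin-4-yl and compound 2 reads 0.146 mg/kg so removing that group is expected to raise the number, by roughly the size of a 3.5-fold lower number from compound 1 to compound 2 (0.55 log units; beyond the scatter) but in the opposite direction. The expected step is a 3.4-fold higher number from compound 2 to compound 3 (0.53 log units; beyond the scatter) in this assay with wide uncertainty on a single precedent. For compound 3 the estimate is 0.5 mg/kg with an expected range from 0.13 mg/kg to 1.9 mg/kg on this thin basis.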

Compound 3, dose for half-maximal effect: 0.0113 mg/kg
Beside the measured number, compound 3's estimate is 44-fold (1.65 log units) above it; measured number below the stated range.
By their numbers in this assay, from the lowest: compound 3; then compound 2; then compound 1.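

In this assay, the group on this aromatic carbon need not be an aromatic ring: acetamido gives a 13-fold lower number from compound 2 to compound 3 (1.11 log units; beyond the scatter), and against the phenyl group it gives a 45-fold lower number from compound 1 to compound 3 (1.66 log units; beyond the scatter). The earlier step only exchanged one six-membered aromatic ring for another, whereas this change removes the ring altogether, brings in fewer heavy atoms and adds a hydrogen-bond donor, and the number still falls rather than rises, so a ring at this position is not required for a low dose in the dog heart read-out. Nothing at hand explains why acetamido reads so far below both ring-bearing compounds.

The compounds shown leave open which part of acetamido carries the step, since the loss of the ring, the smaller group and the amide hydrogen all change together here. A plain amine at this position, an N-methyl acetamido group lacking the amide hydrogen, or a longer chain on the carbonyl would begin to separate these parts.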